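The source may report more compounds than this note shows. Statements on the series, on what has been measured and on what is new or still open speak of the compounds shown alone.

Measured compounds in a functional assay on CFPAC-1 cells (Homo sapiens) for antiproliferative activity, read by MTT assay, with a stated time of 72 h; on this read-out higher numbers stand for weaker inhibition and lower numbers for stronger inhibition:
- compound 1, `O=C1O/C(=C\Cn2cc(-c3cc(C(F)(F)F)cc(C(F)(F)F)c3)nn2)C(OCc2ccccc2)=C1OCc1ccccc1`: compound 1 reaches only the limit > 100000 nM in this assay, a limit and not a number.
- compound 2, `CCCCCCCCCCc1cn(C[C@H](O)[C@H]2OC(=O)C(OCc3ccccc3)=C2OCc2ccccc2)nn1`: compound 2 gives 40300 nM in this assay.
- compound 3, `O=C1O/C(=C\Cn2cc(-c3cccc(O)c3)nn2)C(OCc2ccccc2)=C1OCc1ccccc1`: compound 3 gives 33700 nM in this assay.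

Of the two numeric values, compound 2 holds the higher one, yet the value of compound 3 lies within the usual scatter of it, so the two are not separable. Compound 4, `O=C1O[C@H]([C@@H](O)Cn2cc(CCO)nn2)C(OCc2ccccc2)=C1OCc1ccccc1`, is not yet measured in this assay. It differs from compound 2 by hydroxy in place of octyl on a saturated chain carbon, two bonds along the chain from an aromatic carbon. Among the compounds with values here, with no measured step of this kind on hand, the expectation is a small shift, if any, toward a higher number, possibly reaching the limit. Compound 4 is estimated at 80000 nM (range 30000 nM to 300000 nM), an expected step of a 2.0-fold higher number from compound 2 to compound 4 (0.30 log units; within the scatter).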

Compound 4, half-maximal inhibitory concentration: > 100000 nM
Compound 4: only a limit was reported (the forecaster's own chance of this, stated with the estimate: 50%); at least 1.2-fold (0.09 log units) between middle value and limit.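

In this assay, the exchange of hydroxy for octyl on a saturated chain carbon, two bonds along the chain from an aromatic carbon, gives an at least 2.4-fold higher number from compound 2 to compound 4 (0.39 log units; beyond the scatter), the first step readable in this series. The change therefore moves the read-out beyond the scatter toward weaker inhibition. Its full size cannot be read, since compound 4 gives only a limit: the limit of > 100000 nM in this assay, at which 2 of the 4 values shown sit.

The compounds shown do not separate the loss of the octyl from the arrival of the hydroxy. From the compounds shown here alone, a butyl chain, an amine or a carboxylic acid at this place remains open.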